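From isopropyl to pyridin-2-yl on compound 2

A few compounds are considered here, and "the series" means these few. Any claim that something is new, unique, unknown or untested is made for them only; others in the source may bear on it.

Of the compounds shown here, two have been measured in an ADME assay (liver) for metabolic stability, with Liver microsome (Rattus norvegicus) as the target, using microsomes and NADPH, with a stated time of 30 min, at 37 degrees C, tested at 1 uM; a higher number here means faster removal of the compound, a lower number slower removal. Compound 1 `C[C@H](O)C#Cc1cc(C(O)(C(F)(F)F)C(F)(F)F)cnc1-c1ccc(S(=O)(=O)c2ccc(N)nc2)cc1` gives 29 mL.min-1.g-1, and compound 2 `CC(C)Nc1nc(S(=O)(=O)c2ccc(N)nc2)ccc1-c1ccc(C(C)(O)C(F)(F)F)cn1` gives 62 mL.min-1.g-1. Compound 2 thus holds the higher of the two numbers, with a gap beyond the usual scatter. These two compounds differ in more than one place, so their gap cannot be assigned to any single change. Compound 3 `CC(O)(c1ccc(-c2ccc(S(=O)(=O)c3ccc(N)nc3)nc2Nc2ccccn2)nc1)C(F)(F)F` differs from compound 2 in one place: pyridin-2-yl in place of isopropyl on a nitrogen on an aromatic ring. This puts pyridin-2-yl in place of isopropyl on a nitrogen on an aromatic ring. Among the compounds with values here, no measured pair shows this change, so the expectation is loose: a modest fall in this assay, possibly none beyond the scatter. The estimated change is a 1.5-fold lower number from compound 2 to compound 3 (0.17 log units; within the scatter). For compound 3 the expected value is 42 mL.min-1.g-1, with an estimated range of 16 mL.min-1.g-1 to 105 mL.min-1.g-1.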

Compound 3, intrinsic clearance in microsomes: 130 mL.min-1.g-1
Estimate against measurement, compound 3: 3.1-fold (0.49 log units) below; measured number above the stated range.
By their numbers in this assay, from the lowest: compound 1; then compound 2; then compound 3.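

In this assay, the exchange on a nitrogen on an aromatic ring gives the first comparison among these compounds that differs in one place, and it shows a 2.1-fold higher number from compound 2 to compound 3 (0.32 log units; beyond the scatter), a modest step toward faster removal. The group on this nitrogen therefore matters for this read-out, and pyridin-2-yl is not better tolerated here than isopropyl. Nothing available explains the rise.

This single step cannot separate the contribution of the aromatic ring from that of its ring nitrogen, or from the larger group size, and a phenyl group on the same nitrogen would help to tell these apart. From the compounds shown here alone, it also remains open whether a small saturated ring such as cyclopropyl on this nitrogen would lie nearer to compound 2 or to compound 3.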